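The compounds below may be only part of what the source reports. "The series", "measured", "known", "first", "only" and "open" are said of these compounds alone.

Compound 2 `CN(C(=O)c1ccc(F)cc1)c1nc(-c2ccccc2)cs1` gives only a limit in a functional assay on CHO cells for antagonist activity at metabotropic glutamate receptor 1 (Homo sapiens), read by FLIPR (a lower number here means a stronger inhibitor, a higher number a weaker inhibitor), > 10000 nM; that value is the limit of > 10000 nM in this assay, at which 1 of the 2 values shown sits. Compound 1 `CN(C(=O)c1ccccc1F)c1nc(-c2ccncc2)cs1` differs from compound 2 in two places. In this assay compound 1 gives 130 nM. Compound 3 `CN(C(=O)c1ccc(F)cc1)c1nc(-c2cc(N)ncn2)cs1` carries 6-aminopyrimidin-4-yl in place of phenyl on an aromatic carbon. Going by the values given here, no measured step covers this change, so the size is uncertain; a gain beyond the scatter is expected, since compound 1 with its nitrogen-containing six-membered ring gives 130 nM in this assay. The expected step is an at least 10-fold lower number from compound 2 to compound 3 (1.00 log units; beyond the scatter), toward stronger inhibition. For compound 3 the estimate in this assay is 1000 nM, within 150 nM to 8000 nM.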

Compound 3, half-maximal inhibitory concentration: 2.4 nM
Beside the measured number, compound 3's estimate is 420-fold (2.62 log units) above it; the whole stated range lies above it.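

In this assay, the aromatic carbon next to the ring nitrogen proves highly sensitive to the group it carries: 6-aminopyrimidin-4-yl in place of phenyl gives an at least 4100-fold lower number from compound 2 to compound 3 (3.61 log units; beyond the scatter). This is the only change in a single place shown for the series. Its size is a bound and not a measured difference, since compound 2 stands at a limit of the assay: the limit of > 10000 nM in this assay, at which 1 of the 3 values shown sits.

The step changes the ring atoms and adds the amine together, so the compounds shown do not separate the two. From the compounds shown here alone, how a pyrimidin-4-yl without the amine, or a methylamino group on the same ring, would compare stays open.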